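Amide nitrogen substituents on the shared core

The source may report more compounds than this note shows. Statements on the series, on what has been measured and on what is new or still open speak of the compounds shown alone.

Compound 1 `CCNC(=O)CC1CCc2cc(OC)c(OC)cc21` and compound 2 `CCCCCNC(=O)CC1CCc2cc(OC)c(OC)cc21` share one core and differ only at the amide nitrogen. In a functional assay on the whole organism (strain Wistar) for inhibition, with Rattus norvegicus as the target, read by paw edema, with stated times of 60 min and 6 h, at a dose of 100 mg/kg by the oral route (on this read-out higher numbers stand for more inhibition at the one dose given (going by the name of the read-out) and lower numbers for less inhibition), compound 1 gives 20.4% and compound 2 gives 35.2%. Going by the values given here, the single step measured so far, a number 14.8 percentage points higher from compound 1 to compound 2 (beyond the scatter), came with propyl in place of hydrogen on a saturated chain carbon, two bonds along the chain from an amide-type nitrogen. Compound 2 thus stands highest of the two numbers seen, with compound 1 the nearest and lower by that step. Compound 3 `COc1cc2c(cc1OC)C(CC(=O)NC1CCCCC1)CC2` is not yet measured; it differs from compound 2 by cyclohexyl in place of pentyl on an amide-type nitrogen. Among the compounds with values here, no measured step swaps a chain for a ring; the only step at hand lengthened the chain on the same nitrogen and was modest. Cyclohexyl matches pentyl closely in heavy atoms, so a change that stays within the scatter is expected, with compound 3 estimated at 38% (range 22% to 54%). The expected step, a number 2.8 percentage points higher from compound 2 to compound 3 (within the scatter), is estimated as no real movement.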

Compound 3, a percentage reported as inhibition, in the whole organism at one dose (the size of the read-out at that dose, not a potency): 48.2%
Compound 3: middle estimate off by 10.2 percentage points, on the low side, within the range that was stated.
By their numbers in this assay, from the lowest: compound 1; then compound 2; then compound 3.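

At the amide nitrogen, the read-out in this assay responds to the shape of the substituent as well as to the chain length seen earlier: cyclohexyl in place of pentyl gives a number 13 percentage points higher from compound 2 to compound 3 (beyond the scatter), although the two groups are close in heavy atoms. Against the ethyl of compound 1, cyclohexyl gives a number 27.8 percentage points higher from compound 1 to compound 3 (beyond the scatter), and compound 3 stands highest of the three, with its steps to both others beyond the scatter. The data shown offer no explanation for the gain with the ring.

On these data alone, whether the gain belongs to rings in general or to the six-membered ring in particular stays open, and a cyclopentyl or phenyl on the same nitrogen would bear on that. Also open, as far as these compounds go, is how a longer chain such as octyl, or a chain ending in an amine or a carboxylic acid, would compare with cyclohexyl at this position.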